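Compound 2 to compound 4: methylamino for hydroxy

The source may hold more compounds than are shown below. What is called first, only, known or untested is meant among the compounds shown, and "the series" means these compounds.

Measured in a functional assay on A2780 cells (Homo sapiens) for antiproliferative activity, read by MTT assay, with a stated time of 48 h; on this read-out lower numbers stand for stronger inhibition and higher numbers for weaker inhibition
- compound 1 (`COc1ccc(C(=O)c2ccc(OC)c3c2OC(C)(C)C=C3)c(NC(=O)CO)c1`) gives 100 nM
- compound 2 (`C=C(c1ccc(OC)cc1NC(=O)CO)c1ccc(OC)c2c1C=CC(C)(C)O2`) gives 280 nM
- compound 3 (`C=C(c1ccc2c(c1)C=CC(C)(C)O2)c1ccc(OC)cc1NC(=O)CN`) gives 140 nM

Compound 2 (280 nM) lies within the scatter of compound 3, while its number is higher than that of compound 1 by more than the scatter. The next compound to consider is compound 4 (`C=C(c1ccc(OC)cc1NC(=O)CNC)c1ccc(OC)c2c1C=CC(C)(C)O2`), which keeps the core of compound 2 and carries methylamino in place of hydroxy on a saturated chain carbon bound to a carbonyl carbon.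

Going by the values given here, no measured pair isolates this change, so the expectation rests on thin evidence. Among the compounds with values here, compound 3, the only measured compound with an amino group on that chain, gives 140 nM and stays within the scatter of compound 2, although the two also differ elsewhere. In this assay, a 1.2-fold lower number from compound 2 to compound 4 (0.09 log units; within the scatter) is therefore expected to be small, with no shift beyond the scatter in either direction. Compound 4 is estimated at 230 nM with an expected range of 90 nM to 600 nM in this read-out.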

Compound 4, half-maximal inhibitory concentration: 720 nM
Compound 4: the middle estimate sits 3.1-fold (0.50 log units) below what was measured; the measured number lies above the stated range.
By their numbers in this assay, from the lowest: compounds 1, 3 and 2 (each within the scatter of the next, the first and the last beyond it); then compound 4.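

In this assay, going by these compounds alone, a 2.6-fold higher number from compound 2 to compound 4 (0.41 log units; beyond the scatter) is the first step that isolates a single change, and it lies beyond the scatter, towards weaker inhibition. On a saturated chain carbon bound to a carbonyl carbon, methylamino in place of hydroxy is therefore not a silent exchange on the core of compound 2, although the change adds only one heavy atom and leaves the counts of hydrogen-bond donors and acceptors as they were. Nothing measured here accounts for the size or direction of this step.

Within the data shown here, it remains open whether the loss follows the nitrogen or the methyl on it: a primary amine at this place on the core of compound 2 would separate the two, and compound 3, which carries an amino group on that chain, differs from compound 2 and compound 4 in other places as well, so no step to it can be read. Going by these compounds, the response of this position to a dimethylamino group, a carboxylic acid or a longer chain also remains open.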